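Replacing one fused ring on the amine nitrogen with another

The source may report more compounds than this note shows. Statements on the series, on what has been measured and on what is new or still open speak of the compounds shown alone.

Compound 1 `NS(=O)(=O)OC[C@@H]1C[C@@H](n2nnc3c(NCc4ccccc4F)ncnc32)C[C@@H]1O`: 6.11 nM
Compound 2 `NS(=O)(=O)OC[C@@H]1C[C@@H](n2nnc3c(NCc4ccco4)ncnc32)C[C@@H]1O`: 30.6 nM
Compound 3 `NS(=O)(=O)OC[C@@H]1C[C@@H](n2nnc3c(Nc4cnc5ccccn45)ncnc32)C[C@@H]1O`: > 10000 nM

The three measured compounds share one core and differ only in the group carried on a nitrogen on an aromatic ring. In an assay on a protein complex for inhibition of NEDD8 activating enzyme (Homo sapiens), read by HTRF, with a stated time of 2 h, in the presence of a further agent that is not named here (a higher number here means a weaker inhibitor, a lower number a stronger inhibitor), compound 1 gives 6.11 nM, and compound 2 gives 30.6 nM, a change of a 5.0-fold higher number from compound 1 to compound 2 (0.70 log units; beyond the scatter). For compound 3 the result is a limit of the assay rather than a number, > 10000 nM, as shown by the limit of > 10000 nM in this assay, at which 1 of the 3 values shown sits. Going from the benzylic groups to the fused ring on the nitrogen was costly: an at least 1600-fold higher number from compound 1 to compound 3 (3.21 log units; beyond the scatter) and an at least 320-fold higher number from compound 2 to compound 3 (2.51 log units; beyond the scatter).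

Compound 4 `NS(=O)(=O)OC[C@@H]1C[C@@H](n2nnc3c(Nn4ccc5ccccc54)ncnc32)C[C@@H]1O` keeps that directly attached fused ring but changes its make-up: a group of 9 heavy atoms (8 carbon, 1 nitrogen; one five-membered aromatic ring with 1 hetero atom, one six-membered aromatic ring of carbon only) in place of a group of 9 heavy atoms (7 carbon, 2 nitrogen; one five-membered aromatic ring with 2 hetero atoms, one six-membered aromatic ring with 1 hetero atom), on a nitrogen on an aromatic ring. Going by the values given here, no measured step covers this exact exchange, so the expectation rests on compound 3 standing at the limit. Compound 4 is expected to remain weak in this assay, with an estimated step of an at least 1.2-fold lower number from compound 3 to compound 4 (0.09 log units; that floor lies within the scatter). The estimate for compound 4 is 8000 nM, within a range from 2000 nM to 30000 nM, with a fair chance that only a limit is reported.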

Compound 4, half-maximal inhibitory concentration: > 10000 nM
Compound 4: no number, only a limit (the forecaster's own chance of this, stated with the estimate: 55%); middle value at least 1.2-fold (0.09 log units) from the limit.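

In this assay compound 4 gives > 10000 nM, which is a limit of the assay and not a number, so a second group joins compound 3 at that limit: the limit of > 10000 nM in this assay, at which 2 of the 4 values shown sit.

Against the groups that carry a saturated chain carbon on the nitrogen, 1H-indol-1-yl costs as much as can be read, with an at least 1600-fold higher number from compound 1 to compound 4 (3.21 log units; beyond the scatter) and an at least 320-fold higher number from compound 2 to compound 4 (2.51 log units; beyond the scatter), so the loss at this position does not hang on the one fused group in compound 3. The step between compound 3 and compound 4 cannot be read, which means the swap of ring make-up between them can be neither ranked nor sized.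

The compounds shown leave open whether the loss goes with the missing chain carbon or with the fused ring itself: a plain phenyl set directly on that nitrogen, or a 1H-indol-1-yl held on a methylene chain, would separate the two. As far as these compounds go, how far compound 3 and compound 4 lie beyond the limit also stays unknown.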